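Adding an Amino Acyl Group to Compound 1

The source may hold more compounds than are shown below. What is called first, only, known or untested is meant among the compounds shown, and "the series" means these compounds.

In a functional assay on HCT-116 cells (Homo sapiens) for antiproliferative activity (a lower number here means a stronger inhibitor, a higher number a weaker inhibitor), compound 1 (`Cc1c2c(n3c1CCNC[C@@H](C)[C@H](C)Nc1cc-3ccc1C(N)=O)CC(C)(C)CC2=O`) gives 24 nM. Compound 2 (`CC(=O)N1CCCc2c(C)c3c(n2-c2ccc(C(N)=O)c(c2)N[C@@H](C)[C@@H]1C)CC(C)(C)CC3=O`) gives 27 nM, and these two values lie within the usual scatter of each other, so neither compound stands apart. Compound 3 (`Cc1c2c(n3c1CCN(C(=O)C(C)(C)N)C[C@@H](C)[C@H](C)Nc1cc-3ccc1C(N)=O)CC(C)(C)CC2=O`) has not yet been measured. It carries (1-amino-1-methylethyl)carbonyl in place of hydrogen on an amine nitrogen in a ring of compound 1 ((1-amino-1-methylethyl)carbonyl in place of hydrogen on an amine nitrogen in a ring). Going by the values given here, no measured pair isolates this change, so the expectation has little direct support. A modest loss of activity in this assay is expected, close to the edge of the scatter. The expected step is a 1.7-fold higher number from compound 1 to compound 3 (0.22 log units; within the scatter). The estimated value for compound 3 is 40 nM, with an expected range from 12 nM to 130 nM.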

Compound 3, half-maximal inhibitory concentration: 25 nM
Estimate against measurement, compound 3: 1.6-fold (0.20 log units) above; the measured number falls inside the stated range.
By their numbers in this assay, from the lowest: compounds 1, 3 and 2 (each within the scatter of the next).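

In this assay, placing (1-amino-1-methylethyl)carbonyl on the amine nitrogen in the ring gives a 1.0-fold higher number from compound 1 to compound 3 (0.02 log units; within the scatter), a step within the scatter. This is the first single-place change shown at this position, and it shows that this nitrogen can carry an acyl group of 6 heavy atoms with no measurable change in the number. Nothing measured here bears on why the number holds.

The compounds shown leave open how a hydroxyl or a carboxylic acid in place of the amine of this group would read in this assay. They also leave open whether a longer chain between the carbonyl and the amine, or a simple acetyl on this same nitrogen of compound 1, would keep the number within the scatter.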